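The source may report more compounds than this note shows. Statements on the series, on what has been measured and on what is new or still open speak of the compounds shown alone.

Measured compounds:
- compound 1, `COc1cc(/C=C/C2=CC(=O)CC(c3ccc(O)c(OC)c3)N2CCCO)ccc1O`, in a toxicity assay on CHO-K1 cells (Cricetulus griseus) for cytotoxicity, read by MTT assay, with a stated time of 48 h; on this read-out lower numbers stand for stronger inhibition and higher numbers for weaker inhibition: > 100000 nM, which is a limit of the assay rather than a number.
- compound 2, `COc1cc(/C=C/C(=O)/C=C(/C=C/c2ccc(O)c(OC)c2)NCCO)ccc1O`, in this assay: 87500 nM.

For the measured compounds named here, compound 2 holds the only actual number here; the other value sits at the limit of > 100000 nM in this assay, at which 1 of the 2 values shown sits. Compound 3 `COc1cc(/C=C/C(=O)/C=C(/C=C/c2ccc(O)c(OC)c2)NCCCO)ccc1O` is not yet measured. It differs from compound 2 by hydroxymethyl in place of hydroxy on a saturated chain carbon, two bonds along the chain from an amine nitrogen. Going by the values given here, no step between measured compounds is available to lean on, so the expected change from compound 2 to compound 3 is none beyond the usual scatter of repeated measurements. The estimated step is no change at the digits printed from compound 2 to compound 3 (within the scatter). Compound 3 is therefore expected to give about 87500 nM in this assay, within a range from 40000 nM to 190000 nM.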

Compound 3, half-maximal inhibitory concentration: 88500 nM
The estimate for compound 3 lay 1.0-fold (0.00 log units) below the measured number; measured number inside the range.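

Going from the 2-hydroxyethyl to the 3-hydroxypropyl group on the amine nitrogen gives a 1.0-fold higher number from compound 2 to compound 3 (0.00 log units; within the scatter) in this assay. For the compounds shown here, this is the first comparison of two compounds that differ in one place, and it shows that one added chain carbon at this position leaves the number within the scatter.

Compound 1 gives a limit of the assay rather than a number: the limit of > 100000 nM in this assay, at which 1 of the 3 values shown sits.

Going by these compounds, whether a longer chain, or an amine or a carboxylic acid in place of the hydroxy, would shift the number remains open.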